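A few compounds are considered here, and "the series" means these few. Any claim that something is new, unique, unknown or untested is made for them only; others in the source may bear on it.

Of the compounds shown here, three with a shared core have been measured in a functional assay on HL-60 cells (Homo sapiens) for inhibition, read by MTT assay, with a stated time of 72 h; a higher number here means a weaker inhibitor, a lower number a stronger inhibitor. Compound 1 `Cc1nc(-c2ccccc2)c(C(=O)N2CCN(c3ccc(Cl)c(Cl)c3)CC2)o1` gives 124 nM. Compound 2 `COc1cc(OC)cc(N2CCN(C(=O)c3onc(C)c3-c3ccc(-c4ccco4)cc3)CC2)c1` gives 191 nM, and compound 3 `COc1cc(OC)cc(N2CCN(C(=O)c3onc(C)c3-c3cccc(F)c3)CC2)c1` gives 152 nM. Compound 3 stands between the other two on these numbers, yet its separation from compound 1 and from compound 2 is each within the scatter, so the three cannot be told apart on this evidence. Among the measured compounds shown here, the one single-point step, a 1.3-fold lower number from compound 2 to compound 3 (0.10 log units; within the scatter), changes the aryl group on an aromatic carbon of the five-membered aromatic ring with 1 nitrogen and 1 oxygen, and it stays within the scatter.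

Compound 4 `COc1cc(OC)cc(N2CCN(C(=O)c3onc(C)c3-c3ccccc3F)CC2)c1` is not yet measured. It differs from compound 3 as follows: 2-fluorophenyl in place of 3-fluorophenyl on an aromatic carbon The two have the same atoms, joined differently, and the change sits at the same place that was varied from compound 2 to compound 3. Since that step, a 1.3-fold lower number from compound 2 to compound 3 (0.10 log units; within the scatter), stayed within the scatter, no step beyond the scatter is expected here either, a 1.1-fold higher number from compound 3 to compound 4 (0.02 log units; within the scatter). Compound 4 is therefore estimated at 160 nM, between 75 nM and 340 nM.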

Compound 4, half-maximal inhibitory concentration: 165 nM
The estimate for compound 4 lay 1.0-fold (0.01 log units) below the measured number; the range from low to high includes it.
By their numbers in this assay, from the lowest: compounds 1, 3, 4 and 2 (each within the scatter of the next).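

Exchanging 3-fluorophenyl for 2-fluorophenyl on the aromatic carbon gives a 1.1-fold higher number from compound 3 to compound 4 (0.04 log units; within the scatter) in this assay, so these two isomeric groups cannot be told apart. Putting 2-fluorophenyl in place of 4-(furan-2-yl)phenyl gives a 1.2-fold lower number from compound 2 to compound 4 (0.06 log units; within the scatter), which means that all three aryl groups compared at this carbon now lie within the scatter of one another, whether the change is a different group or the same atoms joined differently. Nothing available offers a reason for this lack of separation.

All the groups shown at this carbon are aryl groups, so it remains open whether an amine, a carboxylic acid or a longer alkyl chain there would give a number in the same range. Also open, from the compounds shown here alone, is whether any change at this place can produce a step beyond the scatter in this assay.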